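This account rests on a few compounds, and the source may have more. Where it says the series, first, only, none or still open, it means among the compounds named here.

Measured in a functional assay on HepG2 cells (Homo sapiens) for cytotoxicity, with a stated time of 72 h; a higher number here means that more compound is needed for the effect, a lower number that less compound is needed:
- Compound 1 `C=C[C@@](C)(/C=C/c1ccc(O)cc1)CC/C=C/C(=O)c1ccccc1`: > 52000 nM
- Compound 2 `COc1ccc(/C=C/[C@@](C)(/C=C/c2ccc(O)c(/C=C/C(C)=O)c2)CCC=C(C)C)cc1`: > 52000 nM
- Compound 3 `CCOc1ccc(/C=C/[C@@](C)(/C=C/c2ccc(O)cc2)CCC=C(C)C)cc1`: > 52000 nM

All three entries are limits of the assay and not numbers. Compound 3 has no exact value and stands with the other two compounds: the limit of > 52000 nM in this assay, at which 3 of the 3 values shown sit.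

Compound 4 `CC(C)=CCC[C@](C)(/C=C/c1ccc(O)cc1)/C=C/c1cccc(Cl)c1` has yet to be measured. It carries 3-chlorophenyl in place of 4-ethoxyphenyl on a double-bonded chain carbon bound to a double-bonded chain carbon. Going by the values given here, no measured step is available to size this change. With all three compounds at that limit, no change beyond the scatter is expected, and another limit is likely. The estimated step is a step that the limit leaves unreadable from compound 3 to compound 4. For compound 4 the expected value is 55000 nM, with an estimated range of 25000 nM to 110000 nM.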

Compound 4, half-maximal effective concentration: > 52000 nM
Compound 4: only a limit was reported; the forecaster's own chance of this, stated with the estimate: 75%; the middle value lies beyond the limit too.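

Compound 3 and compound 4 both stand at a limit of the assay and not at a number, so no step can be read between them: the limit of > 52000 nM in this assay, at which 4 of the 4 values shown sit. The compounds shown leave open which change to the shared core, if any, would give a readable value in this assay.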